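A few compounds are considered here, and "the series" means these few. Any claim that something is new, unique, unknown or untested is made for them only; others in the source may bear on it.

Measured compounds in this series:
- compound 1 `O=C(CCn1c(C(F)(F)F)nc2ccccc21)N/N=C/c1c(O)ccc2ccccc12`: 30000 nM
- compound 2 `Cc1nc2cnccc2n1CCC(=O)N/N=C/c1c(O)ccc2ccccc12`: 90000 nM
- compound 3 `Cc1nccn1CCC(=O)N/N=C/c1c(O)ccc2ccccc12`: 10000 nM

All three share the same hydrazone-linked core and were read in a physicochemical assay for solubility, read by fluorescence and spectrophotometry; a higher number here means a more soluble compound, a lower number a less soluble compound. Compound 2 gives 90000 nM, the highest number of the three, and compound 3 gives 10000 nM, the lowest. Compound 1 gives 30000 nM and stands second highest; its gap to compound 2 lies beyond the scatter, as does its gap to compound 3. For the measured compounds named here, no pair among the three differs in only one place, so no single step can be read from the measured set.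

Compound 4 `[N-]=[N+]=NCc1nc2ccccc2n1CCC(=O)N/N=C/c1c(O)ccc2ccccc12` is not yet measured. It comes from compound 1 by one change:
azidomethyl in place of trifluoromethyl on an aromatic carbon

Nothing measured here speaks directly to this exchange. The three measured compounds span a modest range in this assay, and the change in compound 4 is of a similar size to the differences among them, so the step from compound 1 to compound 4 is expected to be small, plausibly within the scatter, with no firm direction: a 1.3-fold higher number from compound 1 to compound 4 (0.12 log units; within the scatter). Compound 4 is accordingly estimated at 40000 nM, with a range of 15000 nM to 100000 nM.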

Compound 4, solubility: 20000 nM
The estimate for compound 4 lay 2.0-fold (0.30 log units) above the measured number; the range from low to high includes it.
By their numbers in this assay, from the lowest: compounds 3, 4 and 1 (each within the scatter of the next, the first and the last beyond it); then compound 2.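

In this assay, for the compounds shown here, azidomethyl in place of trifluoromethyl on an aromatic carbon gives a 1.5-fold lower number from compound 1 to compound 4 (0.18 log units; within the scatter), the first single-place step, and it lies within the scatter. At this position, between two ring nitrogen atoms and next to the ring atom that bears a large group, one group of 4 heavy atoms can therefore replace another without a separable effect on the reading, even though azidomethyl brings 3 nitrogen in place of 3 fluorine, 2 double bonds outside aromatic rings and 1 hydrogen-bond acceptor. No available evidence offers an account of why compound 1 and compound 4 read alike.

From the compounds shown here alone, whether the position stays this flat for a different kind of substituent remains open, since one exchange cannot show how an amine, a carboxylic acid or a longer chain would read here. Going by these compounds, it also remains open whether azidomethyl in place of trifluoromethyl would read the same way on the core of compound 2 or the core of compound 3, as neither compound is linked to another by a single-place step.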